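Exchanging the benzyl substituent en route to compound 4

The source may report more compounds than this note shows. Statements on the series, on what has been measured and on what is new or still open speak of the compounds shown alone.

Three compounds sharing a hindered phenol core have been characterised in an assay on isolated protein for inhibition of Amine oxidase [flavin-containing] B (Homo sapiens), read by fluorescence, with stated times of 15 min and 20 min; on this read-out higher numbers stand for weaker inhibition and lower numbers for stronger inhibition. Compound 1 `CC(C)(C)c1cc(CCC(=O)NC2CCN(Cc3ccccc3)CC2)cc(C(C)(C)C)c1O` gives 70400 nM. Compound 2 `CC(C)(C)c1cc(/C=C/C(=O)NC2CCN(Cc3ccccc3)CC2)cc(C(C)(C)C)c1O` gives 33500 nM. Compound 3 `COc1ccc(CN2CCC(CCNC(=O)/C=C/c3cc(C(C)(C)C)c(O)c(C(C)(C)C)c3)CC2)cc1` gives 6700 nM, the lowest of the three numbers; its nearest neighbour is compound 2, whose number is higher by a margin beyond the usual scatter, and compound 1 stands further away still.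

Compound 4 `CC(C)(C)c1cc(/C=C/C(=O)NCCC2CCN(Cc3cccc(Cl)c3)CC2)cc(C(C)(C)C)c1O` has not yet been measured in this assay. It differs from compound 3 in one place, (3-chlorophenyl in place of 4-methoxyphenyl on a saturated chain carbon bound to an amine nitrogen in a ring). Among the measured compounds shown here, no pair among the measured compounds isolates this particular change, so there is no measured step to lean on directly. For the measured compounds named here, what is known is only that compound 3, carrying the 4-methoxyphenyl, already reaches the lowest value in the set with 6700 nM.

On that basis the change is expected to leave the number roughly where compound 3 stands or to lower it modestly, with the step of a 1.5-fold lower number from compound 3 to compound 4 (0.17 log units; within the scatter) not expected to move clearly beyond the scatter. Compound 4 is therefore estimated at 4500 nM in this assay, with a plausible range from 1500 nM to 13000 nM.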

Compound 4, half-maximal inhibitory concentration: 8700 nM
The estimate for compound 4 lay 1.9-fold (0.29 log units) below the measured number, and the stated range covers the measured number.
By their numbers in this assay, from the lowest: compounds 3 and 4 (each within the scatter of the next); then compound 2; then compound 1.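

In this assay, placing 3-chlorophenyl where compound 3 carries 4-methoxyphenyl, on a saturated chain carbon bound to an amine nitrogen in a ring, gives a 1.3-fold higher number from compound 3 to compound 4 (0.11 log units; within the scatter), so the two compounds cannot be told apart on this read-out. Among the compounds shown here, this is the first pair that isolates a change at this position, and it shows that 4-methoxybenzyl and 3-chlorobenzyl are interchangeable here as far as this measurement can tell, even though the group that leaves has a hydrogen-bond acceptor and the group that enters has none. Nothing measured alongside these numbers offers an explanation for this result.

The single step alters both the substituent and where it sits on the aromatic ring, so the compounds shown cannot separate those two contributions; that would take a partner carrying 4-chlorophenyl or 3-methoxyphenyl at this place. From the compounds shown here alone, it also remains open whether this position would stay as undemanding with an unsubstituted phenyl, or with a carboxylic acid or an amine on the aromatic ring.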